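Notes on the group carried by the ring nitrogen

The source may hold more compounds than are shown below. What is called first, only, known or untested is meant among the compounds shown, and "the series" means these compounds.

Measured so far:
compound 1, `C=CCn1c(=O)n(C(=O)NCCN2CCN(C)CC2)c2ccccc21`: in a functional assay for agonist activity at 5-hydroxytryptamine receptor 4 (Cavia porcellus) (a higher number here means a larger maximal response, a lower number a smaller maximal response), compound 1 gives 0.63.
compound 2, `CN1CCN(CCNC(=O)n2c(=O)n(C)c3ccccc32)CC1`: in this assay compound 2 gives 0.42.
compound 3, `CCn1c(=O)n(C(=O)NCCN2CCN(C)CC2)c2ccccc21`: in this assay compound 3 gives < 0.3, which is a limit of the assay and not a number.

Compound 3 thus sits at the limit of < 0.3 in this assay, at which 1 of the 3 values shown sits, the lowest of the three, with only a bound known for it. The next compound is compound 4, `CN1CCN(CCNC(=O)n2c(=O)[nH]c3ccccc32)CC1`. Its change from compound 3 is hydrogen in place of ethyl on an aromatic nitrogen. Going by the values given here, no measured step strips the group from the ring nitrogen altogether; the nearest are the steps among the chain groups: a number 0.21 lower from compound 1 to compound 2 (beyond the scatter), a number at least 0.33 lower from compound 1 to compound 3 (beyond the scatter) and a number at least 0.12 lower from compound 2 to compound 3 (beyond the scatter), all beyond the scatter. The smaller chain group gives the higher response in the step from methyl to ethyl, while compound 1, with the vinyl group, goes against that reading and stands highest. For compound 4 a modest rise from compound 3 is expected, a number at least 0.10 higher from compound 3 to compound 4 (that floor lies within the scatter). Compound 4 is estimated at 0.4, within 0.2 to 0.6, with a real chance that this assay again reports only a limit.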

Compound 4, intrinsic activity: the largest response reached, as a fraction of the reference agonist's: 0.35
Beside the measured number, compound 4's estimate is 0.050 above it; the range from low to high includes it.
By their numbers in this assay, from the lowest: compounds 4 and 2 (each within the scatter of the next); then compound 1. At a limit, below all of these: compound 3.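

With hydrogen on the aromatic nitrogen, this assay shows no separation from methyl, a number 0.070 lower from compound 2 to compound 4 (within the scatter), whereas the loss against allyl is clear, a number 0.28 lower from compound 1 to compound 4 (beyond the scatter), so a group on this nitrogen is not needed for the response seen with compound 2, and only allyl in compound 1 stands clear of hydrogen. The change from ethyl gives only a floor, a number at least 0.050 higher from compound 3 to compound 4 (that floor lies within the scatter), so it does not establish that hydrogen improves on ethyl. Compound 3 remains a limit of the assay and not a number: the limit of < 0.3 in this assay, at which 1 of the 4 values shown sits.

From the compounds shown here alone, it remains open whether compound 1 stands alone among chain groups on this nitrogen, or whether propyl, benzyl or a longer chain would also reach its response. Going by these compounds, it is also open whether a chain ending in an amine would be tolerated here.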